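A few compounds are considered here, and "the series" means these few. Any claim that something is new, unique, unknown or untested is made for them only; others in the source may bear on it.

Measured compounds:
compound 1 `Cc1ccc(-c2cn(Cc3ccccc3)c3c2CNCC3)cc1`, 35 nM
compound 2 `CC(C)(C)c1ccc(-c2cn(Cc3ccccc3)c3c2CNCC3)cc1`, 10000 nM
compound 3 `Fc1cccc(-c2cn(Cc3ccccc3)c3c2CNCC3)c1`, 2730 nM

In an assay on HEK293 cells for displacement of a labelled ligand from 5-hydroxytryptamine receptor 7 (Rattus norvegicus), with a stated time of 60 min (a lower number here means a stronger inhibitor, a higher number a weaker inhibitor), compound 3 stands second highest of the three numbers, well above compound 1 and below compound 2. Compound 4 `Fc1ccc(-c2cn(Cc3ccccc3)c3c2CNCC3)cc1` differs from compound 3 only in the fluorophenyl group: 4-fluorophenyl in place of 3-fluorophenyl on an aromatic carbon. Among the measured compounds shown here, no measured step moves a fluorine in this way. The nearest guides are a 78-fold higher number from compound 1 to compound 3 (1.89 log units; beyond the scatter), where 4-methylphenyl became 3-fluorophenyl, and a 290-fold higher number from compound 1 to compound 2 (2.46 log units; beyond the scatter), where tert-butyl replaced methyl. Both show this group matters greatly, but neither tells how 4-fluorophenyl behaves. Because a 78-fold higher number from compound 1 to compound 3 (1.89 log units; beyond the scatter) was large, part of that loss may be recovered, though uncertainly. Compound 4 is expected at 600 nM, with a range from 120 nM to 3000 nM. The expected step is a 4.6-fold lower number from compound 3 to compound 4 (0.66 log units; beyond the scatter).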

Compound 4, inhibition constant: 45 nM
Beside the measured number, compound 4's estimate is 13-fold (1.12 log units) above it; the whole stated range lies above it.
By their numbers in this assay, from the lowest: compounds 1 and 4 (each within the scatter of the next); then compound 3; then compound 2.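

In this assay, moving the fluorine from 3-fluorophenyl to 4-fluorophenyl gives a 61-fold lower number from compound 3 to compound 4 (1.78 log units; beyond the scatter), so where the fluorine sits matters, not merely that it is present. With the group as 4-fluorophenyl, fluoro in place of methyl gives a 1.3-fold higher number from compound 1 to compound 4 (0.11 log units; within the scatter), which leaves the two indistinguishable here, while fluoro in place of tert-butyl gives a 220-fold lower number from compound 2 to compound 4 (2.35 log units; beyond the scatter), so the tert-butyl compound alone stands far off. No measurement available here bears on the cause of these steps. Still open, on these data alone, is how 4-chlorophenyl or 4-methoxyphenyl would behave, and whether 3-methylphenyl would show a loss like that of 3-fluorophenyl.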